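Cutting Back the Chain of Compound 1

This account rests on a few compounds, and the source may have more. Where it says the series, first, only, none or still open, it means among the compounds named here.

For the measured compounds named here, in a functional assay on MDA-MB-231 cells (Homo sapiens) for inhibition, read by MTT assay, with stated times of 18 h and 4 h (a lower number here means a stronger inhibitor, a higher number a weaker inhibitor), compound 1 (`CCCCCCCCCCOP(=O)(O)OCCSC(=S)N1CCCCCC1`) gives the lowest number so far (11400 nM). Compound 2 (`CCCCCCCCCCOP(=O)(O)OCCSC(=S)N1CCCCC1`) gives a higher one (24600 nM). The next candidate, compound 3 (`CCCOP(=O)(O)OCCSC(=S)N1CCCCCC1`), keeps the azepan-1-yl group of compound 1 but changes the chain (hydrogen in place of heptyl on a saturated chain carbon, three bonds along the chain from an oxygen on an unsaturated carbon). In words, this is hydrogen in place of heptyl on a saturated chain carbon, three bonds along the chain from an oxygen on an unsaturated carbon.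

Going by the values given here, only one measured step bears on this, and only indirectly (a 2.2-fold higher number from compound 1 to compound 2 (0.33 log units; beyond the scatter)). It is a modest change, just beyond the scatter, made at the thiocarbonyl carbon and not in the chain. Among the compounds with values here, no measured pair shows what altering the chain does, so the forecast is uncertain. Still, losing heptyl is a much larger edit than swapping azepan-1-yl for piperidin-1-yl, so a larger step than that one is expected in this assay, towards a weaker inhibitor. The estimated change is a 7.0-fold higher number from compound 1 to compound 3 (0.85 log units; beyond the scatter) in this direction. For compound 3 the expected value is about 80000 nM, with an estimated range from 25000 nM to 250000 nM.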

Compound 3, half-maximal inhibitory concentration: 38000 nM
The estimate for compound 3 lay 2.1-fold (0.32 log units) above the measured number, within the range that was stated.
By their numbers in this assay, from the lowest: compound 1; then compounds 2 and 3 (each within the scatter of the next).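

In this assay, putting hydrogen in place of heptyl on a saturated chain carbon, three bonds along the chain from an oxygen on an unsaturated carbon, gives a 3.3-fold higher number from compound 1 to compound 3 (0.52 log units; beyond the scatter) and so moves towards a weaker inhibitor. For the compounds shown here, this is the first measured sign that the chain matters as well as the group on the thiocarbonyl carbon, the only place changed between the two earlier compounds. With heptyl gone, compound 3 still gives a number of 38000 nM in this assay and the step is only modest, while no measurement available here explains why the shortened chain behaves this way.

With only two chain lengths shown alongside the azepan-1-yl group, a butyl or hexyl chain would be needed to tell whether the number climbs steadily as the chain shortens or changes abruptly at some length. Also open, going by these compounds, is whether a chain longer than that of compound 1, such as a dodecyl chain, or a chain ending in an amine would lower the number further.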